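Nitro for trifluoromethoxy: notes on compound 4

A few compounds are considered here, and "the series" means these few. Any claim that something is new, unique, unknown or untested is made for them only; others in the source may bear on it.

In a functional assay on KB cells (Homo sapiens) for inhibition, read by MTT assay, with a stated time of 24 h, tested at 0.1 ug/mL (on this read-out lower numbers stand for less inhibition of growth and higher numbers for more inhibition of growth at the one concentration tested), compound 3 `O=C(CCCCC(S)CCS)Nc1ccc(OC(F)(F)F)cc1` gives 7.27%, within the scatter of both other measured compounds: compound 1 `O=C(CCCCC1CCSS1)Nc1ccc(OC(F)(F)F)cc1` gives 1.97% and compound 2 `O=C(CCCCC(S)CCS)Nc1ccccc1` gives 9.49%. Compound 4 `O=C(CCCCC(S)CCS)Nc1ccc([N+](=O)[O-])cc1` differs from compound 3 as follows: nitro in place of trifluoromethoxy on an aromatic carbon. This places nitro in place of trifluoromethoxy on an aromatic carbon. The closest measured change at that carbon is a number 2.2 percentage points lower from compound 2 to compound 3 (within the scatter). The change on the saturated chain, a number 5.3 percentage points higher from compound 1 to compound 3 (within the scatter), lies elsewhere in the molecule. Among the compounds with values here, no nitro compound has been measured yet, so nothing beyond the scatter is expected in this assay. The expected step is a number 0.7 percentage points higher from compound 3 to compound 4 (within the scatter). For compound 4 the estimate is 8%, with an expected range from 1% to 18%.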

Compound 4, percent growth inhibition at one concentration: "not active" (no number reported)
The entry for compound 4 holds no number; no gap can be computed for the estimate.
By their numbers in this assay, from the lowest: compounds 1, 3 and 2 (each within the scatter of the next).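

Within the data shown here, compound 4 is reported as "not active" without a number, so no step from compound 3 to compound 4 can be read. Nothing available bears on this result. The compounds shown leave open how far nitro in place of trifluoromethoxy shifts growth inhibition.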